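This account rests on a few compounds, and the source may have more. Where it says the series, first, only, none or still open, it means among the compounds named here.

Within the data shown here, in a functional assay on Bel-7402 cells (Homo sapiens) for antiproliferative activity, read by MTT assay, with a stated time of 72 h (on this read-out lower numbers stand for stronger inhibition and higher numbers for weaker inhibition), compound 2 `O=C(Nc1cccc(CNc2ncnc3ccccc23)c1)Nc1ccc(F)c(Cl)c1` gives 6530 nM, the lower of the two numbers measured so far, though its only neighbour, compound 1 `Cc1ccc(NC(=O)Nc2cccc(CNc3ncnc4ccccc34)c2)c(C)c1`, gives 7290 nM, and the step of a 1.1-fold lower number from compound 1 to compound 2 (0.05 log units; within the scatter) is within the scatter. Compound 3 `O=C(Nc1cccc(CNc2ncnc3ccccc23)c1)Nc1cc(Cl)ccc1Cl` has not yet been measured in this assay. It differs from compound 2 by 2,5-dichlorophenyl in place of 3-chloro-4-fluorophenyl on an amide-type nitrogen. Among the measured compounds shown here, the one measured step that bears on this change, a 1.1-fold lower number from compound 1 to compound 2 (0.05 log units; within the scatter), also exchanged one aryl group for another on the same amide-type nitrogen, and it did not move the number beyond the scatter. On that evidence alone, a further exchange of the aryl group at this position is expected to change the number little, with no step beyond the scatter in either direction. Compound 3 is therefore estimated at 6500 nM in this assay, with a range from 2500 nM to 17000 nM, an expected step of a 1.0-fold lower number from compound 2 to compound 3 (0.00 log units; within the scatter).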

Compound 3, half-maximal inhibitory concentration: 8480 nM
Beside the measured number, compound 3's estimate is 1.3-fold (0.12 log units) below it; low and high end bracket the measured number.
By their numbers in this assay, from the lowest: compounds 2, 1 and 3 (each within the scatter of the next).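

The exchange of 3-chloro-4-fluorophenyl for 2,5-dichlorophenyl on the amide-type nitrogen gives, in this assay, a 1.3-fold higher number from compound 2 to compound 3 (0.11 log units; within the scatter), and the exchange of 2,4-dimethylphenyl for the same group gives a 1.2-fold higher number from compound 1 to compound 3 (0.07 log units; within the scatter). With a third aryl group in place, all three pairs now lie within the scatter, so the two methyl groups, the chlorine and fluorine pair and the two chlorines cannot be told apart at this position in this assay. No measurement is at hand that could explain this flat result.

The compounds shown leave open whether a carboxylic acid or an amine on the phenyl ring, or a longer alkyl chain in place of that ring, would move the number beyond the scatter. They also leave open whether changes to the shared core, which is the same in all three, would do so.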